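Chain extension at the aromatic amine: compound 3 to compound 4

The source may hold more compounds than are shown below. What is called first, only, known or untested is meant among the compounds shown, and "the series" means these compounds.

Of the compounds shown here, three have been measured in a functional assay (spleen, spleen) for activation, with Mus musculus as the target; a higher number here means that more compound is needed for the effect, a lower number that less compound is needed. Compound 1 `Nc1nc(SCc2ccccc2)nc2c1nc(O)n2Cc1ccccc1` gives 0.1 uM. Compound 2 `Nc1ncnc2c1nc(O)n2Cc1ccccc1` gives 10 uM. Compound 3 `CCNc1nc(N)c2nc(O)n(Cc3ccccc3)c2n1` gives 1 uM, which places it second highest of the three numbers: its nearest neighbour is compound 1, at a 10-fold higher number from compound 1 to compound 3 (1.00 log units; beyond the scatter), and the furthest is compound 2, at a 10-fold lower number from compound 2 to compound 3 (1.00 log units; beyond the scatter).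

Compound 4 `CCCNc1nc(N)c2nc(O)n(Cc3ccccc3)c2n1` differs from compound 3 by methyl in place of hydrogen on a saturated chain carbon, two bonds along the chain from a nitrogen on an aromatic ring. Within the data shown here, no measured step touches this chain carbon; the measured steps all replace the group on the aromatic carbon itself. Of these, a 10-fold lower number from compound 2 to compound 3 (1.00 log units; beyond the scatter) and a 10-fold higher number from compound 1 to compound 3 (1.00 log units; beyond the scatter) show that a larger group on that carbon went with a lower number, the largest, benzylsulfanyl, giving the lowest number of the three. Adding a single carbon to the ethylamino chain is a far smaller change than either of those steps, so only a small step is expected in this assay, if any beyond the scatter, and more likely downward than upward.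

Compound 4 is therefore estimated at 0.5 uM, with a range from 0.15 uM to 2 uM, corresponding to an expected step of a 2.0-fold lower number from compound 3 to compound 4 (0.30 log units; within the scatter).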

Compound 4, minimum effective concentration: 0.1 uM
Estimate against measurement, compound 4: 5.0-fold (0.70 log units) above; measured number below the stated range.
By their numbers in this assay, from the lowest: compounds 1 and 4 (each within the scatter of the next); then compound 3; then compound 2.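

In this assay, the saturated chain carbon proves to be a sensitive place: methyl in place of hydrogen there gives a 10-fold lower number from compound 3 to compound 4 (1.00 log units; beyond the scatter) and so matches in size the step from the aromatic carbon's hydrogen to ethylamino, a 10-fold lower number from compound 2 to compound 3 (1.00 log units; beyond the scatter). Propylamino on that aromatic carbon gives a 100-fold lower number from compound 2 to compound 4 (2.00 log units; beyond the scatter) and, against the benzylsulfanyl group, no change at the digits printed from compound 1 to compound 4 (within the scatter), which shows that among these compounds the low number of compound 1 is also reached with a plain alkylamino chain and does not depend on benzylsulfanyl. No evidence available for this series accounts for why the added methyl has so large an effect.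

Going by these compounds, with only hydrogen, ethylamino and propylamino along this line, it remains open whether butylamino or a longer chain would continue the fall in the number, hold it level or reverse it. Also open, on these data alone, is how a branched chain such as isopropylamino, or a benzylamino group, would compare with propylamino on the same aromatic carbon.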